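A few compounds are considered here, and "the series" means these few. Any claim that something is new, unique, unknown or untested is made for them only; others in the source may bear on it.

Working notes on the series.

Compound 1 `C#Cc1cn([C@@H]2O[C@H](CO)[C@@H](O)[C@H]2O)c2nc(C)nc(N)c12` reaches only the limit > 100000 nM in an ADME assay on BJ cells (Homo sapiens), read by MTT assay, with a stated time of 72 h; on this read-out higher numbers stand for weaker inhibition and lower numbers for stronger inhibition (the limit of > 100000 nM in this assay, at which 1 of the 3 values shown sits). Compound 2 `Cc1nc(N)c2c(I)cn([C@@H]3O[C@H](CO)[C@@H](O)[C@H]3O)c2n1` gives 24600 nM in this assay, so the step of an at least 4.0-fold lower number from compound 1 to compound 2 (0.60 log units; beyond the scatter) follows the change (iodo in place of ethynyl on an aromatic carbon).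

Compound 3 `C#Cc1cn([C@@H]2O[C@H](CO)[C@@H](O)[C@H]2O)c2ncnc(OC)c12` gives 98400 nM in this assay; the difference between the core of compound 3 and the core of compound 1 is not broken down here.

Compound 4 `COc1ncnc2c1c(I)cn2[C@@H]1O[C@H](CO)[C@@H](O)[C@H]1O` is not yet measured. Its change from compound 3, (iodo in place of ethynyl on an aromatic carbon), is the same change seen between compound 1 and compound 2, at the same place. Resting on the step of an at least 4.0-fold lower number from compound 1 to compound 2 (0.60 log units; beyond the scatter), the expected step is a 4.9-fold lower number from compound 3 to compound 4 (0.69 log units; beyond the scatter), though that earlier step starts from a limit and its true size is uncertain. Compound 4 is therefore estimated at 20000 nM in this assay, expected between 5000 nM and 80000 nM.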

Compound 4, half-maximal inhibitory concentration: 91000 nM
For compound 4 the middle estimate is 4.6-fold (0.66 log units) below the measured one; measured number outside the range, above it.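

Iodo in place of ethynyl on an aromatic carbon gives a 1.1-fold lower number from compound 3 to compound 4 (0.03 log units; within the scatter) in this assay, so the change does not carry over from one core to the other at the same size: the same change on two cores in this assay, an at least 4.0-fold lower number (0.60 log units; beyond the scatter) from compound 1 to compound 2 and a 1.1-fold lower number (0.03 log units; within the scatter) from compound 3 to compound 4, at least 3.7-fold (0.57 log units) apart, beyond the scatter of two such steps

This shows a dependence on the core for these two pairs only; it does not show which difference between the cores is responsible, or how the change behaves on any third core. Compound 1 stands at a limit, not at a number, so the true size of the earlier step stays unknown: the limit of > 100000 nM in this assay, at which 1 of the 4 values shown sits.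

Open, on these data alone, is how bromo, chloro or an amine at the same place would read on either core. Also open, as far as these compounds go, is whether a methoxy group alone, on the core of compound 1, would separate the two steps.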